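Quinolinone imines: hydroxy for carboxy on the aryl ring

A few compounds are considered here, and "the series" means these few. Any claim that something is new, unique, unknown or untested is made for them only; others in the source may bear on it.

Compound 1 `Cc1ccc2[nH]c(=O)c(/C=N/c3ccc(C(=O)O)cc3)cc2c1` carries a carboxy group on its aryl ring and in a functional assay, read by spectrophotometry, with a stated time of 1 h (on this read-out higher numbers stand for weaker inhibition and lower numbers for stronger inhibition), compound 1 is recorded as "not active" (no number reported), with no number reported. Two related hydrazones give weak numbers in this assay: compound 2 `O=c1[nH]c2ccccc2cc1/C=N/Nc1ccccc1` gives 1000000 nM and compound 3 `O=c1[nH]c2ccccc2cc1/C=N/Nc1ccc([N+](=O)[O-])cc1[N+](=O)[O-]` gives 375000 nM. Compound 4 `Cc1ccc2[nH]c(=O)c(/C=N/c3ccc(O)cc3)cc2c1` differs from compound 1 in one place: hydroxy in place of carboxy on an aromatic carbon. Among the compounds with values here, no measured step exists for this change, so its size in this assay is unknown; on the evidence of compound 2 and compound 3, no shift beyond the scatter is expected, and a limit rather than a number is likely. Compound 4 is therefore expected to give 600000 nM, estimated within 150000 nM to 2000000 nM.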

Compound 4, half-maximal inhibitory concentration: "not active" (no number reported)
Nothing numeric was reported for compound 4, so the estimate cannot be set against anything.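

Compound 1 and compound 4 both lack a reported number, so no step can be read between them. The compounds shown leave open what hydroxy in place of carboxy does to inhibition. No evidence bears on this result.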